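Swapping a selenium-bearing chain for a sulfur-bearing amide

The compounds below may be only part of what the source reports. "The series", "measured", "known", "first", "only" and "open" are said of these compounds alone.

Compound 2 `CC(=O)Oc1ccccc1C(=O)[Se]CC[Se]C#N` carries a selenoester linked to a selenocyanate-bearing chain on the acetylated salicylate core. Going by the values given here, in a functional assay on HT-29 cells (Homo sapiens) for antiproliferative activity, read by MTT assay, with a stated time of 72 h (on this read-out lower numbers stand for stronger inhibition and higher numbers for weaker inhibition), compound 2 gives 17700 nM, the lowest of the two numbers measured so far, yet its nearest neighbour compound 1 `CC(=O)Oc1ccccc1C(=O)OCC[Se]C#N` gives 20200 nM, and the step of a 1.1-fold lower number from compound 1 to compound 2 (0.06 log units; within the scatter) lies within the scatter. Compound 3 `CC(=O)Oc1ccccc1C(=O)NCCSC#N` differs from compound 2 in that (a group of 6 heavy atoms (3 carbon, 2 nitrogen, 1 sulfur; no ring) in place of a group of 6 heavy atoms (3 carbon, 1 nitrogen, 2 selenium; no ring), on a carbonyl carbon). Among the compounds with values here, only the one measured step bears on this change, and it altered a single atom in the same chain without moving the number beyond the scatter. The present change replaces both selenium atoms and adds an amide hydrogen, so it is larger than anything measured, and the expected step of a 1.6-fold higher number from compound 2 to compound 3 (0.20 log units; within the scatter) is uncertain but is not anticipated to exceed the scatter clearly. Compound 3 is therefore estimated at 28000 nM, within a range from 10000 nM to 80000 nM.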

Compound 3, half-maximal inhibitory concentration: > 50000 nM
Compound 3: a limit, no number; the forecaster's own chance of this, stated with the estimate: 15%; middle value at least 1.7-fold (0.25 log units) away from the limit.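

The value of compound 3 in this assay is a limit of the assay and not a number: the limit of > 50000 nM in this assay, at which 1 of the 3 values shown sits. Even so, the limit is enough to give an at least 2.8-fold higher number from compound 2 to compound 3 (0.45 log units; beyond the scatter) and an at least 2.4-fold higher number from compound 1 to compound 3 (0.39 log units; beyond the scatter). So, unlike the step between the oxygen and selenium links of compound 1 and compound 2, this change on a carbonyl carbon moves the read-out beyond the scatter, towards weaker inhibition.

The change brings in nitrogen with the amide hydrogen and puts sulfur in place of selenium at the same time, so the compounds shown cannot say which part of it matters. On these data alone, whether a 2-(selenocyanato)ethylamino group on the same carbonyl carbon would track compound 2 or compound 3 stays open, as does how far the true value of compound 3 lies past its limit.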